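The source may report more compounds than this note shows. Statements on the series, on what has been measured and on what is new or still open speak of the compounds shown alone.

Measured compounds and their values:
- Compound 1 `CCOc1ccc(N2C[C@@H](C)N[C@@H](C)C2)cc1NS(=O)(=O)c1ccc(-c2ccccn2)s1`: 0.8 in a functional assay for agonist activity at growth hormone secretagogue receptor type 1 (Homo sapiens), read by FLIPR; on this read-out lower numbers stand for smaller maximal responses and higher numbers for larger maximal responses
- Compound 2 `CC(C)Oc1ccc(N2C[C@@H](C)N[C@@H](C)C2)cc1NS(=O)(=O)c1ccc(-c2ccccn2)s1`: 1.1 in this assay
- Compound 3 `COc1cccc(-c2ccc(S(=O)(=O)Nc3cc(N4C[C@@H](C)N[C@@H](C)C4)ccc3OC)cc2)c1`: 1 in this assay

Compound 3 stands second highest of the three values in this assay. Its nearest neighbour is compound 2, whose value lies within the scatter of its own, so no order between the two can be read. Its furthest neighbour is compound 1, whose value lies lower by an amount beyond the scatter.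

For the measured compounds named here, the one measured step, a number 0.30 higher from compound 1 to compound 2 (beyond the scatter), concerns the saturated chain carbon bound to the oxygen on the aromatic ring, a part of the shared core that is left untouched between compound 3 and compound 4 `COc1ccc(N2C[C@@H](C)N[C@@H](C)C2)cc1NS(=O)(=O)c1ccc(-n2cccn2)cc1`. The change leading to compound 4 is 1H-pyrazol-1-yl in place of 3-methoxyphenyl on an aromatic carbon. Going by the values given here, no measured step touches this position, so the step from compound 3 to compound 4 in this assay cannot be anchored in a precedent; the three values sit in a narrow band, and the expectation is for a step of no more than the scatter, in either direction.

Compound 4 is therefore estimated at 0.9 in this assay, with a range from 0.6 to 1.1, which means an expected step of a number 0.10 lower from compound 3 to compound 4 (within the scatter).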

Compound 4, intrinsic activity: the largest response reached, as a fraction of the reference agonist's: 0.8
Compound 4: the middle estimate sits 0.10 above what was measured, and the stated range covers the measured number.
By their numbers in this assay, from the lowest: compounds 1 and 4 (each within the scatter of the next); then compounds 3 and 2 (each within the scatter of the next).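

In this assay, the aromatic carbon para to a large group now has a measured step of its own: 1H-pyrazol-1-yl in place of 3-methoxyphenyl gives a number 0.20 lower from compound 3 to compound 4 (beyond the scatter). The earlier compounds shown here offered only a change on the saturated chain carbon bound to the oxygen, a number 0.30 higher from compound 1 to compound 2 (beyond the scatter), so they gave no sign that this other position could move the maximal response by more than the scatter; this exchange shows that it can, though only modestly, with compound 4 still giving a clear response of 0.8. No measurement here accounts for the step.

The exchange alters several things at once, going from a six-membered ring of carbon only with 8 heavy atoms to a five-membered ring with 2 hetero atoms and 5 heavy atoms, so these compounds cannot show which of those differences goes with the step. Going by these compounds, whether an unsubstituted phenyl, a pyridin-2-yl or a 1H-imidazol-1-yl on the same aromatic carbon would fall with compound 3 or with compound 4 remains open.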